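Thiazole for Thiophene at the Aryl Ether Core

The compounds below may be only part of what the source reports. "The series", "measured", "known", "first", "only" and "open" are said of these compounds alone.

Measured compounds:
compound 1, `c1cncc(-c2ccccc2OCC2=NCCN2)c1`, in a functional assay for activation of Alpha-1B adrenergic receptor (Homo sapiens), read by calcium flux (on this read-out higher numbers stand for an effect only at larger amounts of compound and lower numbers for an effect already at smaller amounts), compound 1 gives 79.4 nM.
compound 2, `c1ccc(-c2ccsc2)c(OCC2=NCCN2)c1`, in this assay compound 2 gives 15.9 nM.

Compound 2 holds the lowest number of the two measured in this assay; its nearest neighbour is compound 1, and the step of a 5.0-fold lower number from compound 1 to compound 2 (0.70 log units; beyond the scatter) is beyond the scatter. Compound 3, `c1ccc(-c2nccs2)c(OCC2=NCCN2)c1`, has not yet been measured in this assay. It differs from compound 2 in one place: 1,3-thiazol-2-yl in place of thiophen-3-yl on an aromatic carbon.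

Among the compounds with values here, only one measured step exists, a 5.0-fold lower number from compound 1 to compound 2 (0.70 log units; beyond the scatter), and it does not show this exact change: there, a six-membered ring with one nitrogen gave way to a five-membered ring with one sulfur. The change to compound 3 keeps the five-membered ring but adds a nitrogen and shifts the attachment. Within the data shown here, no measured pair shows a thiazole against a thiophene, so the direction rests on the single comparison that replacing a nitrogen-containing aromatic ring with a sulfur-only ring lowered the number in this assay. On that basis compound 3 is expected to give a modestly higher number than compound 2, a step of a 2.5-fold higher number from compound 2 to compound 3 (0.40 log units; beyond the scatter), with wide uncertainty. The estimate for compound 3 in this assay is 40 nM, within 12 nM to 130 nM.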

Compound 3, half-maximal effective concentration: 20 nM
For compound 3 the middle estimate is 2.0-fold (0.30 log units) above the measured one, and the stated range covers the measured number.
By their numbers in this assay, from the lowest: compounds 2 and 3 (each within the scatter of the next); then compound 1.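

In this assay, the step of a 1.3-fold higher number from compound 2 to compound 3 (0.10 log units; within the scatter) shows that this position accepts 1,3-thiazol-2-yl as readily as thiophen-3-yl: the added ring nitrogen and the new point of attachment, on an aromatic carbon ortho to a group of 7 heavy atoms, leave the number inside the usual scatter. The second comparison, a 4.0-fold lower number from compound 1 to compound 3 (0.60 log units; beyond the scatter), lies beyond the scatter, so both five-membered rings now stand apart from pyridin-3-yl among the three compounds, with none going against that split, and a ring nitrogen as such does not go with the higher number, since compound 1 and compound 3 each carry one. Nothing available explains why the six-membered ring and the two five-membered rings separate in this way.

Within the data shown here, with only three rings compared at this one position, it remains open whether the split follows ring size at all, and a plain phenyl ring or a pyrimidin-5-yl ring would be needed to test that. Also open, going by these compounds, is whether a non-aromatic group here, such as an amine or a carboxylic acid, would keep the number in this assay near that of the five-membered rings.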